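Swapping the Aryl Ring on a Sulfonamide: Compound 3 Expected

The source may report more compounds than this note shows. Statements on the series, on what has been measured and on what is new or still open speak of the compounds shown alone.

Measured so far:
compound 1 `CCCCNC(=O)CCC(NS(=O)(=O)c1cc(Cl)ccc1Cl)C(=O)NCCCC`, in a functional assay on IMR-32 cells (Homo sapiens) for cytotoxicity, read by MTT assay, tested at 60 ug/mL (on this read-out higher numbers stand for more inhibition at the one concentration tested (going by the name of the read-out) and lower numbers for less inhibition), compound 1 gives 15.8%
compound 2 `CCCCNC(=O)CCC(NS(=O)(=O)c1cc(C)ccc1Cl)C(=O)NCCCC`, in this assay compound 2 gives 18%

Compound 2 has the higher of the two numbers, but the step of a number 2.2 percentage points higher from compound 1 to compound 2 (within the scatter) is within the scatter, so the two compounds cannot be told apart on this read-out.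

Compound 3 `CCCCNC(=O)CCC(NS(=O)(=O)c1ccc(C)cc1C)C(=O)NCCCC` is the next compound, so far unmeasured. It differs from compound 2 by 2,4-dimethylphenyl in place of 2-chloro-5-methylphenyl on a sulfonyl sulfur.

For the measured compounds named here, the only measured step, a number 2.2 percentage points higher from compound 1 to compound 2 (within the scatter), also changes a substituent on the same aromatic ring, and it did nothing beyond the scatter. Going by the values given here, that is the only guide to how the number in this assay moves with such changes, and it points to a level number. The expected step is therefore no change at the digits printed from compound 2 to compound 3 (within the scatter), no larger than the scatter.

Compound 3 is estimated at 18%, expected to fall between 8% and 30%.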

Compound 3, a percentage reported as inhibition, at one concentration (the size of the read-out at that concentration, not a potency): 46.1%
Beside the measured number, compound 3's estimate is 28.1 percentage points below it; the whole stated range lies below it.
By their numbers in this assay, from the lowest: compounds 1 and 2 (each within the scatter of the next); then compound 3.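

The aromatic group on the sulfonyl sulfur can clearly shift the result in this assay: 2,4-dimethylphenyl in place of 2-chloro-5-methylphenyl gives a number 28.1 percentage points higher from compound 2 to compound 3 (beyond the scatter) and shows that this position is not indifferent to every change of ring. 2,4-Dimethylphenyl in place of 2,5-dichlorophenyl gives a number 30.3 percentage points higher from compound 1 to compound 3 (beyond the scatter) and so places the one ring without chlorine clearly above both rings that carry it. Nothing measured here explains the rise.

Going by these compounds, the step from compound 2 to compound 3 both replaces a chlorine and changes where a methyl group sits, so the effect of each change on its own remains unknown. Also open, on these data alone, is how a methoxy group or an unsubstituted phenyl ring would fare on the sulfonyl sulfur, and what an amine or a carboxylic acid would do elsewhere on the shared core.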